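The source may report more compounds than this note shows. Statements on the series, on what has been measured and on what is new or still open speak of the compounds shown alone.

Of the compounds shown here, three have been tested in a functional assay on NCI-H460 cells (Homo sapiens) for cytotoxicity, read by MTT assay, with a stated time of 72 h; on this read-out lower numbers stand for stronger inhibition and higher numbers for weaker inhibition. Compound 1, `COc1cc2c(Oc3ccc(NC(=O)c4cc(-c5ccccc5)ccn4)cc3F)ccnc2cc1OCCCN1CCCC1`, gives 130 nM. Compound 2, `COc1cc2c(Oc3ccc(NC(=O)c4cc(-c5ccccc5C)ccn4)cc3F)ccnc2cc1OCCCN1CCCC1`, gives 420 nM in this assay. Compound 3, `COc1cc2c(Oc3ccc(NC(=O)c4nccc(-c5ccccc5)n4)cc3F)ccnc2cc1OCCCN1CCCCC1`, is built on a different core and gives 330 nM in this assay; the difference between the two cores is not broken down here.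

The change from compound 1 to compound 2 is methyl in place of hydrogen on an aromatic carbon and it made a step of a 3.2-fold higher number from compound 1 to compound 2 (0.51 log units; beyond the scatter).

Compound 4, `COc1cc2c(Oc3ccc(NC(=O)c4nccc(-c5ccc(C)cc5)n4)cc3F)ccnc2cc1OCCCN1CCCCC1`, has not been measured yet. It differs from compound 3 by methyl in place of hydrogen on an aromatic carbon. Among the compounds with values here, this is the same kind of change as the one from compound 1 to compound 2, but not the same: in compound 2 the methyl sits ortho to a large group, while in compound 4 it sits para to a large group. Because the earlier step of a 3.2-fold higher number from compound 1 to compound 2 (0.51 log units; beyond the scatter) turned out to weaken inhibition, a higher number is also expected for compound 4, though a smaller shift seems more likely, as the place of the methyl is not identical and the core is a different one. The step expected from compound 3 to compound 4 in this assay is a 1.5-fold higher number from compound 3 to compound 4 (0.18 log units; within the scatter). For compound 4 the estimate in this assay is 500 nM, with a likely range from 250 nM to 1200 nM.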

Compound 4, half-maximal inhibitory concentration: 230 nM
Compound 4: the middle estimate sits 2.2-fold (0.34 log units) above what was measured; measured number outside the range, below it.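

In this assay, changing phenyl to 4-methylphenyl gives a 1.4-fold lower number from compound 3 to compound 4 (0.16 log units; within the scatter), so this methyl, para to a large group, leaves no clear mark on the number. What this does not show is why the outcome differs from the earlier methyl step: the methyl sits in a different place in compound 2 than in compound 4, the cores differ as well, and these two pairs cannot tell which of those differences matters. Even so, the two steps do not match, so the result of this change on one core is a poor guide to its result on the other: the same change on two cores in this assay, a 3.2-fold higher number (0.51 log units; beyond the scatter) from compound 1 to compound 2 and a 1.4-fold lower number (0.16 log units; within the scatter) from compound 3 to compound 4, 4.6-fold (0.67 log units) apart, beyond the scatter of two such steps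

Still open, on these data alone, is whether a methyl on the phenyl of compound 3, placed as it is in compound 2, would give a step like the one seen on the core of compound 1, a single comparison that would help separate the place of the methyl from the core. Also open, as far as these compounds go, is how a chlorine atom, a methoxy group or an amine in the place of the methyl of compound 4 would read in this assay.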